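Chalcones on a shared core: antiproliferative read-out

This account rests on a few compounds, and the source may have more. Where it says the series, first, only, none or still open, it means among the compounds named here.

Compound 1 `COc1ccc(/C=C/C(=O)c2ccc(OC)c3c2OC(C)(C)C=C3)c(F)c1`: in a functional assay on HepG2 cells (Homo sapiens) for antiproliferative activity, read by MTT assay, with a stated time of 24 h (on this read-out lower numbers stand for stronger inhibition and higher numbers for weaker inhibition), compound 1 gives 7560 nM.
Compound 2 `COc1ccc(C(=O)/C=C/c2ccsc2)c2c1C=CC(C)(C)O2`: in this assay compound 2 gives > 10000 nM, a limit of the assay.
Compound 3 `COc1ccc(C(=O)/C=C/c2ccc(O)c(Br)c2)c2c1C=CC(C)(C)O2`: in this assay compound 3 gives > 10000 nM, a limit of the assay.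

Compound 3 stands at the limit of the assay, without a number of its own; see (the limit of > 10000 nM in this assay, at which 2 of the 3 values shown sit). Only compound 1 carries a number. Hence an at least 1.3-fold higher number from compound 1 to compound 3 (0.12 log units; that floor lies within the scatter) is readable only as a floor, and a step that the two limits leave unreadable from compound 2 to compound 3 cannot be read at all. Compound 4 `COc1ccc(C(=O)/C=C/c2cc(Cl)ccc2O)c2c1C=CC(C)(C)O2` differs from compound 3 by 5-chloro-2-hydroxyphenyl in place of 3-bromo-4-hydroxyphenyl on a double-bonded chain carbon bound to a double-bonded chain carbon. Within the data shown here, no measured step changes this aryl group between two numbers; both an at least 1.3-fold higher number from compound 1 to compound 2 (0.12 log units; that floor lies within the scatter) and an at least 1.3-fold higher number from compound 1 to compound 3 (0.12 log units; that floor lies within the scatter) end at the limit. Compound 4 is therefore expected to sit at or near the limit again, and the step that the limit leaves unreadable from compound 3 to compound 4 is expected to stay within the scatter. For compound 4 the estimate in this assay is 12000 nM, with a range from 5000 nM to 30000 nM.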

Compound 4, half-maximal inhibitory concentration: 6640 nM
Beside the measured number, compound 4's estimate is 1.8-fold (0.26 log units) above it; the range from low to high includes it.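

In this assay compound 4 gives this position on the chain a second number, so not every change here ends at the limit: the limit of > 10000 nM in this assay, at which 2 of the 4 values shown sit. Against the two limits only floors can be read, an at least 1.5-fold lower number from compound 3 to compound 4 (0.17 log units; that floor lies within the scatter) and an at least 1.5-fold lower number from compound 2 to compound 4 (0.17 log units; that floor lies within the scatter), so neither step shows a change beyond the scatter. Among these compounds, the one step between two numbers, a 1.1-fold lower number from compound 1 to compound 4 (0.06 log units; within the scatter), puts 5-chloro-2-hydroxyphenyl and 2-fluoro-4-methoxyphenyl level.

The compounds shown do not separate the hydroxyl from the chlorine in 5-chloro-2-hydroxyphenyl. From the compounds shown here alone, how an amine or a carboxylic acid on this aryl ring would read stays open.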